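Swapping chloro for methyl on the amide-linked ring

The source may hold more compounds than are shown below. What is called first, only, known or untested is meant among the compounds shown, and "the series" means these compounds.

Measured so far:
compound 1 `CN1C[C@H](C(=O)Nc2cccc(Cl)c2)[C@@H](c2ccc(/C=C/C(=O)Nc3ccccc3N)cc2)C1` gives 7 mL/min/kg
compound 2 `Cc1cccc(NC(=O)[C@H]2CN(C)C[C@@H]2c2ccc(/C=C/C(=O)Nc3ccccc3N)cc2)c1` gives 14 mL/min/kg
compound 3 `CN1C[C@H](C(=O)Nc2ccc(Cl)c(Cl)c2)[C@@H](c2ccc(/C=C/C(=O)Nc3ccccc3N)cc2)C1` gives 14 mL/min/kg

All three were tested in an in vitro ADME assay on microsomes from liver (Homo sapiens) for pharmacokinetics, read by LC-MS, with a stated time of 10 min, tested at 1 uM; on this read-out higher numbers stand for fast clearance and lower numbers for slow clearance. Compound 1 sits at the low end of the three numbers, while compound 2 and compound 3 stand level with each other. From compound 1 to compound 2 the change is methyl in place of chloro on an aromatic carbon, and the step is a 2.0-fold higher number from compound 1 to compound 2 (0.30 log units; within the scatter). From compound 1 to compound 3 the change is chloro in place of hydrogen on an aromatic carbon, with a step of a 2.0-fold higher number from compound 1 to compound 3 (0.30 log units; within the scatter). Compound 2 and compound 3 differ by a larger swap, and the step is no change at the digits printed from compound 2 to compound 3 (within the scatter). None of these steps reaches beyond the usual scatter.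

Compound 4 `Cc1cc(NC(=O)[C@H]2CN(C)C[C@@H]2c2ccc(/C=C/C(=O)Nc3ccccc3N)cc2)ccc1Cl` has not yet been measured. It differs from compound 3 by methyl in place of chloro on an aromatic carbon. Within the data shown here, this is the same kind of change as the one from compound 1 to compound 2, not the same change: in compound 4 the place is ortho to a chloro group and meta to a large group, whereas in compound 2 the place is only meta to a large group. The two cores differ as described by chloro in place of hydrogen on an aromatic carbon.

Because the earlier swap gave a 2.0-fold higher number from compound 1 to compound 2 (0.30 log units; within the scatter), compound 4 is expected to move little from compound 3, with an estimated step of a 1.3-fold higher number from compound 3 to compound 4 (0.11 log units; within the scatter). The number expected for compound 4 in this assay is 18 mL/min/kg, with a likely range from 9 mL/min/kg to 36 mL/min/kg.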

Compound 4, clearance: 15 mL/min/kg
For compound 4 the middle estimate is 1.2-fold (0.08 log units) above the measured one; the measured number falls inside the stated range.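

In this assay, methyl in place of chloro on an aromatic carbon gives a 1.1-fold higher number from compound 3 to compound 4 (0.03 log units; within the scatter), and the same swap can be compared across the two cores: the same change on two cores in this assay, a 2.0-fold higher number (0.30 log units; within the scatter) from compound 1 to compound 2 and a 1.1-fold higher number (0.03 log units; within the scatter) from compound 3 to compound 4, 1.9-fold (0.27 log units) apart, within the scatter of two such steps. Chloro in place of hydrogen on an aromatic carbon gives a 1.1-fold higher number from compound 2 to compound 4 (0.03 log units; within the scatter), and it too can be compared across two cores: the same change on two cores in this assay, a 2.0-fold higher number (0.30 log units; within the scatter) from compound 1 to compound 3 and a 1.1-fold higher number (0.03 log units; within the scatter) from compound 2 to compound 4, 1.9-fold (0.27 log units) apart, within the scatter of two such steps. Taking 4-chloro-3-methylphenyl in place of 3-chlorophenyl gives a 2.1-fold higher number from compound 1 to compound 4 (0.33 log units; beyond the scatter), the only step here beyond the scatter and a modest one, so these swaps carry from one core to another without a detectable difference, but this shows only agreement among small steps on a few closely related compounds and does not prove that each swap has the same size on every core.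

From the compounds shown here alone, it remains open whether a very different group in the same place on the aromatic ring, such as an amine, a carboxylic acid or a nitrile, would leave clearance as little changed. Going by these compounds, it is also open whether the same swaps would hold up with a longer chain in place of the methyl on the nitrogen of the shared core.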